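Methoxy in Place of Hydrogen Among Compounds at the Limit

The source may hold more compounds than are shown below. What is called first, only, known or untested is meant among the compounds shown, and "the series" means these compounds.

Compound 1, `Cc1ccccc1Nc1nc(C)c(C(=O)/C=C/c2ccccc2Cl)s1`, gives > 25000 nM in a functional assay on NCI-H460 cells (Homo sapiens) for cytotoxicity, read by MTT assay (on this read-out lower numbers stand for stronger inhibition and higher numbers for weaker inhibition), which is a limit of the assay and not a number.
Compound 2, `COc1cccc(/C=C/C(=O)c2sc(Nc3ccc(Cl)cc3)nc2C)c1`, gives > 25000 nM in this assay, again a limit.
Compound 3, `Cc1ccccc1Nc1nc(C)c(C(=O)/C=C/c2ccccc2)s1`, gives > 25000 nM in this assay, also a limit.

Compound 3 therefore stands where every measured value sits, at the limit of the assay, as the limit of > 25000 nM in this assay, at which 3 of the 3 values shown sit, shows. Within the data shown here, the one measured step that touches it, a step that the two limits leave unreadable from compound 1 to compound 3, cannot be read because both ends are limits.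

Compound 4, `COc1cccc(/C=C/C(=O)c2sc(Nc3ccccc3C)nc2C)c1`, differs from compound 3 by methoxy in place of hydrogen on an aromatic carbon. Among the measured compounds shown here, no measured step shows the effect of this change on its own. Compound 2 carries the same 3-methoxyphenyl and sits at the limit, so nothing suggests that the methoxy group brings a value into the readable range. Compound 4 is therefore expected to remain at the limit, with a step that the limit leaves unreadable from compound 3 to compound 4 as the estimated step in this assay and an estimate of 40000 nM, ranging from 15000 nM to 120000 nM.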

Compound 4, half-maximal inhibitory concentration: > 25000 nM
Compound 4: no number, only a limit (the forecaster's own chance of this, stated with the estimate: 85%); the middle value lies beyond the limit too.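

No new step can be read, since compound 4 joins compound 1, compound 2 and compound 3 at a limit of the assay and not a number: the limit of > 25000 nM in this assay, at which 4 of the 4 values shown sit.

The compounds shown leave open how methoxy in place of hydrogen, or any other change among them, acts on the value in this assay.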